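The source may report more compounds than this note shows. Statements on the series, on what has been measured and on what is new or still open speak of the compounds shown alone.

Compound 1 `Cc1ccccc1Cc1cnc(N)nc1N`: in an assay for inhibition of Dihydrofolate reductase (Gallus gallus) (a higher number here means a weaker inhibitor, a lower number a stronger inhibitor), compound 1 gives 29500 nM.
Compound 2 `COc1ccccc1Cc1cnc(N)nc1N`: in this assay compound 2 gives 28800 nM.

Both compounds share one core and differ only in the small group on the attached benzene ring. For the measured compounds named here, on the numbers so far, compound 2 stands level with compound 1: a 1.0-fold lower number from compound 1 to compound 2 (0.01 log units; within the scatter). Swapping methyl for methoxy at that one position therefore left the inhibition constant essentially unchanged.

Compound 3 `Nc1ncc(Cc2ccccc2F)c(N)n1` is the next variation at the same place. It differs from compound 2 by fluoro in place of methoxy on an aromatic carbon: the fluoro enters on an aromatic carbon of a six-membered aromatic ring of carbon only, ortho to a group of 9 heavy atoms, where the methoxy leaves.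

Going by the values given here, only one measured step bears on this change, the step of a 1.0-fold lower number from compound 1 to compound 2 (0.01 log units; within the scatter), which exchanged one small group for another at exactly this position and stayed within the scatter. With a single such comparison, the expectation for this assay is a step no larger than the scatter, in no particular direction: the estimated step is a 1.0-fold higher number from compound 2 to compound 3 (0.02 log units; within the scatter). Compound 3 is thus expected to give about 30000 nM, with a range from 12000 nM to 75000 nM.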

Compound 3, inhibition constant: 43700 nM
The estimate for compound 3 lay 1.5-fold (0.16 log units) below the measured number; the range from low to high includes it.
By their numbers in this assay, from the lowest: compounds 2, 1 and 3 (each within the scatter of the next).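

With fluoro, a third small group has now been placed on this aromatic carbon, ortho to a group of 9 heavy atoms, and in this assay the result again stays within the scatter: the step is a 1.5-fold higher number from compound 2 to compound 3 (0.18 log units; within the scatter), and the comparison with the methyl compound gives a 1.5-fold higher number from compound 1 to compound 3 (0.17 log units; within the scatter). The earlier pair showed only that methyl and methoxy could not be told apart, whereas these steps extend that to fluoro, a single heavy atom that, unlike methoxy, counts no hydrogen-bond acceptor, so neither of those differences comes with a step beyond the scatter in these three compounds. No measurement at hand offers an explanation for this level result.

The compounds shown leave open whether a quite different group at this position, such as an amine, a carboxylic acid or a longer chain, would move the inhibition constant beyond the scatter. They also leave open whether methyl, methoxy and fluoro would stay level if placed on another carbon of the same ring.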